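This account rests on a few compounds, and the source may have more. Where it says the series, first, only, none or still open, it means among the compounds named here.

Measured so far in a functional assay on ECa-109 cells for inhibition, with ECa-109 cell line (Homo sapiens) as the target, read by sulforhodamine B assay; on this read-out lower numbers stand for stronger inhibition and higher numbers for weaker inhibition:
compound 1 `O=C1C=C(NC2CCCC2)C(=O)c2c1nc1n2[C@H]2OC[C@@H](O)[C@H]2OC1` — compound 1 gives > 16000 nM, which is a limit of the assay.
compound 2 `COc1ccc(NC2=CC(=O)c3c(nc4n3[C@H]3OC[C@@H](O)[C@H]3OC4)C2=O)cc1` — compound 2 gives 3410 nM.
compound 3 `COc1cccc(NC2=CC(=O)c3c(nc4n3[C@H]3OC[C@@H](O)[C@H]3OC4)C2=O)c1` — compound 3 gives 3340 nM.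

Compound 1, the cyclopentyl amine, stands only at a limit, (the limit of > 16000 nM in this assay, at which 1 of the 3 values shown sits). Compound 2 and compound 3, both aryl amines, give numbers. Among the compounds with values here, the only measured step, a 1.0-fold lower number from compound 2 to compound 3 (0.01 log units; within the scatter), moves a methoxy group on an aryl amine and is within the scatter; no measured step exchanges an alkyl amine for an aryl amine.

Compound 4 `O=C1C=C(Nc2ccc(I)cc2)C(=O)c2c1nc1n2[C@H]2OC[C@@H](O)[C@H]2OC1` differs from compound 1 by 4-iodophenyl in place of cyclopentyl on an amine nitrogen.

Since compound 2 gives 3410 nM and compound 3 gives 3340 nM, compound 4 as a further aryl amine is expected to land near them. The expected step is an at least 5.0-fold lower number from compound 1 to compound 4 (0.69 log units; beyond the scatter). Compound 4 is estimated at 3200 nM, between 900 nM and 12000 nM.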

Compound 4, half-maximal inhibitory concentration: 2300 nM
Estimate against measurement, compound 4: 1.4-fold (0.14 log units) above; measured number inside the range.
By their numbers in this assay, from the lowest: compounds 4, 3 and 2 (each within the scatter of the next). At a limit, above all of these: compound 1.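

In this assay, within the data shown here, 4-iodophenyl in place of cyclopentyl on the amine nitrogen gives an at least 6.9-fold lower number from compound 1 to compound 4 (0.84 log units; beyond the scatter), the first measured exchange of a non-aromatic ring for an aromatic one at this place. Compound 1 stands at a limit, so this step is a bound and not a size: the limit of > 16000 nM in this assay, at which 1 of the 4 values shown sits. Compound 4 does not separate from the methoxyphenyl amines compound 2 and compound 3.

Still open, on these data alone, is whether the aromatic ring itself is what matters, which a benzyl amine could test. The compounds shown also leave open how an unsubstituted phenyl amine or a phenyl amine bearing a carboxylic acid would read.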